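The source may hold more compounds than are shown below. What is called first, only, known or untested is meant among the compounds shown, and "the series" means these compounds.

In an assay on isolated protein for inhibition of serine/threonine-protein kinase TNNI3K (Homo sapiens) (a lower number here means a stronger inhibitor, a higher number a weaker inhibitor), three close relatives of a shared core have been measured. Compound 1, with the structure `CNc1cc(Oc2ccc(NC(=O)Nc3cccc(C(F)(F)F)c3)cc2Cl)ncn1`, gives 50 nM. Compound 2, `CNc1cc(Oc2ccc(NC(=O)Nc3cccc(C(F)(F)F)c3)cc2)ncn1`, gives 40 nM. Compound 3, `CNc1cc(Oc2c(C)cc(NC(=O)Nc3cccc(C(F)(F)F)c3)cc2C)ncn1`, gives 25 nM. Among the measured compounds shown here, the one step among them that changes a single place is a 1.3-fold lower number from compound 1 to compound 2 (0.10 log units; within the scatter), a change too small to count as a real difference. Compound 3 sits at the low end of the three numbers, but its gaps to compound 2 and to compound 1 both fall within the usual scatter, so none of the three can be called more potent than another.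

Compound 4, `CNc1cc(Oc2ccc(NC(=O)Nc3cccc(C(F)(F)F)c3)cc2C)ncn1`, has not yet been measured. It differs from compound 3 by hydrogen in place of methyl on an aromatic carbon. For the measured compounds named here, the only measured step that resembles this, the loss of a small aromatic substituent from compound 1 to compound 2, stayed within the scatter. The expectation is therefore that compound 4 will show a step of about a 1.4-fold higher number from compound 3 to compound 4 (0.15 log units; within the scatter) in this assay, that is, no change beyond the scatter. Compound 4 is thus estimated at 35 nM, within a range from 15 nM to 80 nM.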

Compound 4, half-maximal inhibitory concentration: <= 10 nM
Compound 4: no number, only a limit; the forecaster's own chance of this, stated with the estimate: 2%; middle value at least 3.5-fold (0.54 log units) from the limit.
By their numbers in this assay, from the lowest: compounds 3, 2 and 1 (each within the scatter of the next). At a limit, below all of these: compound 4.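

In this assay, compound 4 has a limit and not an exact number, so its steps give only a smallest possible size: the limit of <= 10 nM in this assay, at which 1 of the 4 values shown sits. Taking away one of the two methyl groups, at the place ortho to the (6-(methylamino)pyrimidin-4-yl)oxy group, gives an at least 2.5-fold lower number from compound 3 to compound 4 (0.39 log units; beyond the scatter), while adding a single methyl group to the unsubstituted ring gives an at least 4.0-fold lower number from compound 2 to compound 4 (0.60 log units; beyond the scatter), so the ring with one methyl group beats both the ring with two and the ring with none. Swapping chloro for methyl gives an at least 5.0-fold lower number from compound 1 to compound 4 (0.69 log units; beyond the scatter), which shows that this position can respond to its substituent, something a 1.3-fold lower number from compound 1 to compound 2 (0.10 log units; within the scatter) did not reveal.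

As far as these compounds go, how far compound 4 lies beyond its limit remains open, and with it the full size of these steps. Also open, from the compounds shown here alone, is how this position would respond to a fluoro, methoxy or ethyl group.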